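Fluoro for Hydroxy on the Aryl Ketone of a Chalcone

This account rests on a few compounds, and the source may have more. Where it says the series, first, only, none or still open, it means among the compounds named here.

Three chalcones have so far been measured in an assay on isolated protein for inhibition of DNA topoisomerase 1 (Homo sapiens), tested at 100 uM; on this read-out lower numbers stand for a weaker effect and higher numbers for a stronger effect at the one concentration tested. Compound 1 `O=C(/C=C/c1ccc(N2CCCC2)cc1)c1ccc(O)cc1` gives 74.7% and stands second highest of the three numbers: its nearest neighbour is compound 3 `COc1ccc(/C=C/C(=O)c2ccc(F)cc2)cc1Br`, which gives 76.5%, a number within the scatter of compound 1, while compound 2 `COc1ccc(/C=C/C(=O)c2ccc(O)cc2)cc1Br` gives 24.8%, far lower than compound 1 and beyond the scatter.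

The unmeasured compound 4 `O=C(/C=C/c1ccc(N2CCCC2)cc1)c1ccc(F)cc1` arises from compound 1 by one change: fluoro in place of hydroxy on an aromatic carbon. For the measured compounds named here, the single measured step that bears on this change is the one between compound 2 and compound 3, which carries the same exchange of hydroxy for fluoro on an aromatic carbon and gives a number 51.7 percentage points higher from compound 2 to compound 3 (beyond the scatter). That step was large and upward. Compound 1, however, already sits close to compound 3 on this assay, so the room left for a comparable rise is small. Compound 4 is therefore expected to come out at or somewhat above compound 1, an estimated step of a number 7.3 percentage points higher from compound 1 to compound 4 (within the scatter). The value of compound 4 in this assay is estimated at 82%, with a range from 68% to 93%.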

Compound 4, a percentage reported as inhibition, at one concentration (the size of the read-out at that concentration, not a potency): 90.6%
Beside the measured number, compound 4's estimate is 8.6 percentage points below it; the range from low to high includes it.
By their numbers in this assay, from the lowest: compound 2; then compounds 1 and 3 (each within the scatter of the next); then compound 4.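

In this assay, the exchange of 4-hydroxyphenyl for 4-fluorophenyl now has a second reading, on the core of compound 1, and it gives a number 15.9 percentage points higher from compound 1 to compound 4 (beyond the scatter). The direction seen on the core of compound 2 therefore holds on a second core, and in both pairs the fluoro compound gives the higher number. The size of the rise, however, does not carry over from one core to the other: the same change on two cores in this assay, a number 51.7 percentage points higher (beyond the scatter) from compound 2 to compound 3 and a number 15.9 percentage points higher (beyond the scatter) from compound 1 to compound 4, 35.8 percentage points apart, beyond the scatter of two such steps

A methoxy group, a chloro or an amine at this position, or plain hydrogen, would help to separate what fluoro itself contributes from what follows on the loss of hydroxy. Still open, from the compounds shown here alone, are how large the step would be on a third core and what sets its size on each core.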